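Shortening the sulfanyl chain on the shared core

The source may hold more compounds than are shown below. What is called first, only, known or untested is meant among the compounds shown, and "the series" means these compounds.

Of the compounds shown here, three with a shared core have been measured in a functional assay (spleen, spleen) for activation, with Mus musculus as the target; a lower number here means that less compound is needed, a higher number that more compound is needed for the effect. Compound 3 `CCc1nc(N)c2nc(O)n(Cc3ccccc3)c2n1` gives 1 uM, which is the highest of the three numbers, so the most compound is needed for the effect. Compound 1 `CCCCCNc1nc(N)c2nc(O)n(Cc3ccccc3)c2n1` gives 0.1 uM, and compound 2 `CCCCSc1nc(N)c2nc(O)n(Cc3ccccc3)c2n1` gives 0.01 uM. The step of a 10-fold higher number from compound 1 to compound 3 (1.00 log units; beyond the scatter) and the step of a 100-fold higher number from compound 2 to compound 3 (2.00 log units; beyond the scatter) set compound 3 apart from both.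

Compound 4 `CSc1nc(N)c2nc(O)n(Cc3ccccc3)c2n1` has not yet been measured. Its change from compound 3 is methylsulfanyl in place of ethyl on an aromatic carbon.

The step that bears most directly on this change is a 100-fold higher number from compound 2 to compound 3 (2.00 log units; beyond the scatter), since there a butylsulfanyl group stood where compound 3 carries ethyl. The step of a 10-fold lower number from compound 1 to compound 2 (1.00 log units; beyond the scatter) also shows that a sulfanyl group with a four-carbon chain gave a lower number than a pentylamino group. Methylsulfanyl brings in the sulfur but only a single carbon, so a gain in this assay is expected for compound 4, though smaller than the gain from compound 3 back to compound 2, which is estimated as a 3.3-fold lower number from compound 3 to compound 4 (0.52 log units; beyond the scatter).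

Compound 4 is therefore expected to give about 0.3 uM in this assay, within a range of 0.03 uM to 3 uM.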

Compound 4, minimum effective concentration: 0.1 uM
For compound 4 the middle estimate is 3.0-fold (0.48 log units) above the measured one, within the range that was stated.
By their numbers in this assay, from the lowest: compound 2; then compounds 1 and 4 (each within the scatter of the next); then compound 3.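

In this assay, a sulfur on this aromatic carbon makes a clear difference even with only one carbon attached: a 10-fold lower number from compound 3 to compound 4 (1.00 log units; beyond the scatter), although methylsulfanyl and ethyl each count two heavy atoms. The length of the chain on the sulfur matters too, as a 10-fold higher number from compound 2 to compound 4 (1.00 log units; beyond the scatter), a change that cuts the butylsulfanyl group of compound 2 back to the methylsulfanyl group of compound 4. The short methylsulfanyl group also does as well as the much longer pentylamino group, with no change at the digits printed from compound 1 to compound 4 (within the scatter), so chain length alone does not set the number across these compounds.

Compound 1 and compound 2 differ in both the linking atom and the chain, so butylamino or pentylsulfanyl on the shared core would be needed to separate those two effects, while ethylsulfanyl and propylsulfanyl would show how the number moves between the methylsulfanyl and butylsulfanyl groups. Nothing available here gives a measured reason for any of these steps.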